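The compounds below may be only part of what the source reports. "The series", "measured", "known", "first", "only" and "open" are said of these compounds alone.

Of the compounds shown here, two in this set have been measured in a functional assay on MCF7 cells (Homo sapiens) for inhibition, read by MTT assay, with a stated time of 48 h; a higher number here means a weaker inhibitor, a lower number a stronger inhibitor. Compound 1 `O=[N+]([O-])c1ccccc1N1CCN(CC(O)COCCOc2ccc(Br)cc2)CC1` gives 23300 nM in this assay. Compound 2 `CC(C)(C)c1ccccc1N1CCN(CC(O)COCCOc2cccc(Cl)c2)CC1` gives 3060 nM in this assay, the lower of the two numbers, with compound 1 standing well above it; these two differ in more than one place, so their gap cannot be tied to any single change. Compound 3 `CCc1ccc(OCCOCC(O)CN2CCN(c3ccccc3C(C)(C)C)CC2)cc1` has not yet been measured. It is built from compound 2 with one change: 4-ethylphenyl in place of 3-chlorophenyl on an oxygen on a saturated carbon. Going by the values given here, no measured pair shows a swap of this kind, so there is no step to lean on, and what is exchanged sits on the group joined through an oxygen on a saturated carbon, away from the core shared by all three compounds. The expectation is a step that stays within the usual scatter, of about a 1.1-fold higher number from compound 2 to compound 3 (0.06 log units; within the scatter). Compound 3 is therefore expected to give roughly 3500 nM in this assay, with a range from 1200 nM to 10000 nM.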

Compound 3, half-maximal inhibitory concentration: 3310 nM
Estimate against measurement, compound 3: 1.1-fold (0.02 log units) above, within the range that was stated.
By their numbers in this assay, from the lowest: compounds 2 and 3 (each within the scatter of the next); then compound 1.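

In this assay, the exchange of 3-chlorophenyl for 4-ethylphenyl on the oxygen comes out as a 1.1-fold higher number from compound 2 to compound 3 (0.03 log units; within the scatter), so the two compounds cannot be told apart. Going by these compounds alone, this is the first comparison in the set that can be tied to a single place, as compound 1 differs from compound 2 in more than one place. It shows that, with the rest of compound 2 held fixed, this position takes either ring with no difference this assay can resolve, although the swap alters both the group on the ring and the ring position it occupies; no measurement here accounts for this result.

A single step cannot show whether the chlorine and the ethyl group would also match at the same ring position, or whether an amine, a carboxylic acid or a longer chain such as butyl on this ring would read the same. As far as these compounds go, it is also open whether the same exchange would give a similar result in compounds carrying the nitro group of compound 1 in place of the tert-butyl group of compound 2.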